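Indoline for dimethylpiperidine on the diazepanone core

The compounds below may be only part of what the source reports. "The series", "measured", "known", "first", "only" and "open" are said of these compounds alone.

Compound 2 `COc1ccc2[nH]c(C(=O)N3CC(=O)N(Cc4ccccc4)[C@@H](N4[C@H](C)CCC[C@@H]4C)C3)cc2c1` stands lowest of the two numbers in an ADME assay on Vero cells (Chlorocebus sabaeus) for cytotoxicity, with a stated time of 7 days; on this read-out higher numbers stand for lower toxicity in this test and lower numbers for higher toxicity in this test: compound 2 gives 1400 nM, while compound 1 `COc1ccc2[nH]c(C(=O)N3CC(=O)N(Cc4ccccc4)[C@@H](CN4CCCCC4)C3)cc2c1` gives 76900 nM. Going by the values given here, the one known step, a 55-fold lower number from compound 1 to compound 2 (1.74 log units; beyond the scatter), changed the same saturated ring carbon but with a different group, so it bears only loosely on the present change. Compound 3 `COc1ccc2[nH]c(C(=O)N3CC(=O)N(Cc4ccccc4)[C@@H](N4CCc5ccccc54)C3)cc2c1` differs from compound 2 by 2,3-dihydro-1H-indol-1-yl in place of 2,6-dimethylpiperidin-1-yl on a saturated ring carbon. Among the compounds with values here, with no direct precedent, a modest move back toward the higher number is expected, a 3.6-fold higher number from compound 2 to compound 3 (0.55 log units; beyond the scatter). Compound 3 is estimated at 5000 nM, within 1000 nM to 30000 nM.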

Compound 3, half-maximal cytotoxic concentration: > 100000 nM
Compound 3: a limit, no number; the forecaster's own chance of this, stated with the estimate: 5%; middle value at least 20-fold (1.30 log units) from the limit.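

In this assay, compound 3 gives a limit and not a number: the limit of > 100000 nM in this assay, at which 1 of the 3 values shown sits.

At this saturated ring carbon, 2,3-dihydro-1H-indol-1-yl in place of 2,6-dimethylpiperidin-1-yl gives an at least 71-fold higher number from compound 2 to compound 3 (1.85 log units; beyond the scatter), so the low number of compound 2 does not extend to both ring amines shown here. Against the (piperidin-1-yl)methyl group the reading is an at least 1.3-fold higher number from compound 1 to compound 3 (0.11 log units; that floor lies within the scatter), which supports no order between those two compounds.

The limit leaves the full size of both steps open. Also open, from the compounds shown here alone, is how a plain piperidin-1-yl or a morpholin-4-yl on this carbon would read against compound 2.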